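A benzyl nitrile in place of a dimethylphenyl cap

The compounds below may be only part of what the source reports. "The series", "measured", "known", "first", "only" and "open" are said of these compounds alone.

Compound 1 `Cc1ccc(-n2cc(CNC(=O)c3cccc4c3cnn4C(C)C)nn2)c(C)c1` carries a 2,4-dimethylphenyl group on an aromatic nitrogen of the shared core. In a functional assay on MGC-803 cells (Homo sapiens) for inhibition, read by MTT assay, with a stated time of 72 h (a lower number here means a stronger inhibitor, a higher number a weaker inhibitor), compound 1 gives > 40000 nM, which is a limit of the assay and not a number. Compound 2 `CC(C)n1ncc2c(C(=O)NCc3cn(-c4cccc(Br)c4)nn3)cccc21` has a 3-bromophenyl group in that place; in this assay compound 2 gives > 40000 nM, again only a limit. Compound 3 `CC(C)n1ncc2c(C(=O)NCc3cn(-c4cccc(F)c4)nn3)cccc21` has a 3-fluorophenyl group there, and in this assay compound 3 gives > 40000 nM, also a limit. The steps a step that the two limits leave unreadable from compound 1 to compound 2, a step that the two limits leave unreadable from compound 1 to compound 3 and a step that the two limits leave unreadable from compound 2 to compound 3 therefore cannot be sized, because every value sits at the limit of > 40000 nM in this assay, at which 3 of the 3 values shown sit. Nothing in these three compounds shows that changing the aromatic cap moves inhibition into the measurable range.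

Compound 4 `CC(C)n1ncc2c(C(=O)NCc3cn(Cc4ccc(C#N)cc4)nn3)cccc21` differs from compound 1 by 4-cyanobenzyl in place of 2,4-dimethylphenyl on an aromatic nitrogen. Within the data shown here, no measured step bears on this change with a readable size, so there is no evidence pointing toward a gain. Compound 4 is therefore estimated at 40000 nM, with a range from 10000 nM to 100000 nM, and most likely reported as a limit once more. That estimate means an expected step of a number no higher from compound 1 to compound 4 (the limit leaves the size open), which is no change beyond the scatter.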

Compound 4, half-maximal inhibitory concentration: 39600 nM
For compound 4 the middle estimate is 1.0-fold (0.00 log units) above the measured one; measured number inside the range.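

Among these compounds, compound 4 is the first compound in this set to give a real number rather than a limit: in this assay compound 4 gives 39600 nM, which makes a number no higher from compound 1 to compound 4 (the limit leaves the size open), a number no higher from compound 3 to compound 4 (the limit leaves the size open) and a number no higher from compound 2 to compound 4 (the limit leaves the size open). This shows that with 4-cyanobenzyl on the aromatic nitrogen, inhibition can just be read in this assay, but only at the very edge of the measurable range, so it is no evidence of a useful gain. The steps to compound 4 from compounds 1, 2 and 3 cannot be read, because each of them starts from a limit, and so their size stays open: the limit of > 40000 nM in this assay, at which 3 of the 4 values shown sit.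

The new group differs from the earlier aromatic caps in two ways at once, as it brings both a nitrile and a benzyl form of attachment, and the compounds shown do not tell which of these, if either, matters; a plain benzyl group or a 4-cyanophenyl group would separate the two. On these data alone, it also remains open whether a different group on this nitrogen, such as a 4-aminobenzyl group or a longer chain ending in a carboxylic acid, would bring inhibition well clear of the limit.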